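The compounds below may be only part of what the source reports. "The series", "measured", "known", "first", "only" and "open" are said of these compounds alone.

In an assay on isolated protein for inhibition of tyrosine-protein kinase receptor UFO (Homo sapiens), read by FRET and Z'-LYTE, with a stated time of 1.5 h (on this read-out lower numbers stand for stronger inhibition and higher numbers for weaker inhibition), compound 1 `Cc1ccc2c(c1)c(=O)c(C(=O)Nc1ccc(Oc3ncnc4[nH]cc(-c5ccccc5)c34)c(F)c1)c(-c1ccccc1)n2C` gives 78 nM. Compound 2 `CCc1ccc2c(c1)c(=O)c(C(=O)Nc1ccc(Oc3ccnc(Cl)c3)c(F)c1)c(C)n2C` reaches only the limit of this assay, > 10000 nM; this is the limit described in the limit of > 10000 nM in this assay, at which 1 of the 2 values shown sits, not a number, so compound 2 stands at the weak end of the two values shown. Compound 3 `CCc1ccc2c(c1)c(=O)c(C(=O)Nc1ccc(Oc3ccnc(C(N)=O)c3)c(F)c1)c(C)n2C` differs from compound 2 by carbamoyl in place of chloro on an aromatic carbon. Without a measured step of this kind, compound 3 is expected to gain somewhat beyond the scatter, by about an at least 3.3-fold lower number from compound 2 to compound 3 (0.52 log units; beyond the scatter). Compound 3 is therefore estimated at 3000 nM, within 300 nM to 15000 nM.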

Compound 3, half-maximal inhibitory concentration: 4380 nM
Estimate against measurement, compound 3: 1.5-fold (0.16 log units) below; measured number inside the range.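

On the aromatic carbon next to the ring nitrogen, carbamoyl in place of chloro brings a number that can be read in this assay, with an at least 2.2-fold lower number from compound 2 to compound 3 (0.35 log units; beyond the scatter). On these data alone, this step sets only a lower bound on the change, and its full size stays unknown. The value of compound 2 is a limit, not a number: the limit of > 10000 nM in this assay, at which 1 of the 3 values shown sits.

As far as these compounds go, whether an amine, a carboxylic acid or a methylcarbamoyl at this position would read stronger or weaker than carbamoyl stays open. So does whether the same change would hold with the other groups of compound 1.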